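The source may report more compounds than this note shows. Statements on the series, on what has been measured and on what is new or still open speak of the compounds shown alone.

Compound 1 `CC1=C(C(=O)OC(C)(C)C)C(c2ccoc2)NC(=O)N1` was tested in an assay on membranes from CHO cells for displacement of a labelled ligand from adenosine receptor A1 (Homo sapiens), read by scintillation counting, with a stated time of 60 min, tested at 1 uM (a lower number here means less inhibition, a higher number more inhibition at the concentration tested (going by the name of the read-out)), where compound 1 gives 11%. Compound 2 `CC1=C(C(=O)OC(C)(C)C)C(c2cccs2)NC(=O)N1` differs from compound 1 in one place: thiophen-2-yl in place of furan-3-yl on a saturated ring carbon. In this assay compound 2 gives 26%, so that a number 15 percentage points higher from compound 1 to compound 2 (beyond the scatter). Compound 3 `CCSC(=O)C1=C(C)NC(=O)NC1c1ccoc1` differs from compound 1 elsewhere, and this is how the two cores differ: ethylsulfanyl in place of tert-butoxy on a carbonyl carbon. In this assay compound 3 gives 3%, and a number 8 percentage points lower from compound 1 to compound 3 (within the scatter). Compound 4 `CCSC(=O)C1=C(C)NC(=O)NC1c1cccs1` has not yet been measured in this assay. It differs from compound 3 in the same way that compound 2 differs from compound 1: thiophen-2-yl in place of furan-3-yl on a saturated ring carbon. The surroundings are not identical word for word: in compound 3 the saturated ring carbon is next to the ring atom that bears a (ethylsulfanyl)carbonyl group (5 heavy atoms), whereas in compound 1 that ring atom bears a group of 7 heavy atoms, so this is the same kind of change rather than the same change. Resting on a number 15 percentage points higher from compound 1 to compound 2 (beyond the scatter), a gain of similar size is expected for compound 4, namely a number 14 percentage points higher from compound 3 to compound 4 (beyond the scatter). Compound 4 is therefore estimated at 17%, likely between 3% and 33%.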

Compound 4, a percentage reported as inhibition, at one concentration (the size of the read-out at that concentration, not a potency): 6%
The estimate for compound 4 lay 11 percentage points above the measured number; low and high end bracket the measured number.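

In this assay, putting thiophen-2-yl in place of furan-3-yl on the core of compound 3 gives a number 3 percentage points higher from compound 3 to compound 4 (within the scatter), and this step does not differ beyond the scatter from the same change on the core of compound 1: the same change on two cores in this assay, a number 15 percentage points higher (beyond the scatter) from compound 1 to compound 2 and a number 3 percentage points higher (within the scatter) from compound 3 to compound 4, 12 percentage points apart, within the scatter of two such steps. Putting ethylsulfanyl in place of tert-butoxy on the thiophen-2-yl compounds gives a number 20 percentage points lower from compound 2 to compound 4 (beyond the scatter), and this step also agrees with its counterpart on the furan-3-yl compounds: the same change on two cores in this assay, a number 8 percentage points lower (within the scatter) from compound 1 to compound 3 and a number 20 percentage points lower (beyond the scatter) from compound 2 to compound 4, 12 percentage points apart, within the scatter of two such steps. Both changes are therefore compatible with carrying over from one core to the other, but this does not show that their sizes are the same, since each comparison rests on a single pair of steps and in each pair one step lies within the scatter and the other beyond it.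

The compounds shown leave open how a phenyl ring on the saturated ring carbon would behave, or an amine or a longer alkyl chain on the carbonyl carbon. They also leave open the potency of any of these compounds, as the read-out comes from one concentration only.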